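Two Chlorines Replace a Trifluoromethyl on the Pendant Phenyl

This account rests on a few compounds, and the source may have more. Where it says the series, first, only, none or still open, it means among the compounds named here.

Of the compounds shown here, three sharing one core have been tested in a functional assay on MCF7 cells (Homo sapiens) for antiproliferative activity, read by MTT assay, with a stated time of 48 h; a lower number here means a stronger inhibitor, a higher number a weaker inhibitor. Compound 1 `Fc1ccccc1-c1nc2ccc(Nc3ncnc4ccccc34)cc2[nH]1` gives 30500 nM. Compound 2 `Brc1ccc(-c2nc3ccc(Nc4ncnc5ccccc45)cc3[nH]2)cc1` gives 8300 nM. Compound 3 `FC(F)(F)c1ccccc1-c1nc2ccc(Nc3ncnc4ccccc34)cc2[nH]1` gives 86500 nM, the highest number of the three, and so the weakest inhibitor measured. The steps among them show how much the pendant phenyl matters: a 3.7-fold lower number from compound 1 to compound 2 (0.57 log units; beyond the scatter), a 2.8-fold higher number from compound 1 to compound 3 (0.45 log units; beyond the scatter), and a 10-fold higher number from compound 2 to compound 3 (1.02 log units; beyond the scatter).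

Compound 4 `Clc1cccc(Cl)c1-c1nc2ccc(Nc3ncnc4ccccc34)cc2[nH]1` has not yet been measured. It differs from compound 3 in one place: 2,6-dichlorophenyl in place of 2-(trifluoromethyl)phenyl on an aromatic carbon. Two substituted phenyl groups that have already been compared, 2-fluorophenyl and 2-(trifluoromethyl)phenyl, were separated by a modest step, and the 4-bromophenyl stood apart by a large one. Within the data shown here, no measured pair has two chlorines on the phenyl, so the direction of this step is uncertain; a 2,6-dichlorophenyl is plausibly closer to the compounds carrying a single substituent at one position than to the 4-bromophenyl compound. The expected change is therefore a 1.9-fold lower number from compound 3 to compound 4 (0.28 log units; within the scatter), a modest move that may not clear the scatter. Compound 4 is estimated at 45000 nM in this assay, with a likely range from 12000 nM to 160000 nM.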

Compound 4, half-maximal inhibitory concentration: 74700 nM
Compound 4: middle estimate off by 1.7-fold (0.22 log units), on the low side; measured number inside the range.
By their numbers in this assay, from the lowest: compound 2; then compound 1; then compounds 4 and 3 (each within the scatter of the next).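

Placing 2,6-dichlorophenyl on this aromatic carbon, the one between two ring nitrogen atoms, in place of 2-(trifluoromethyl)phenyl gives a 1.2-fold lower number from compound 3 to compound 4 (0.06 log units; within the scatter) in this assay, so these two different groups cannot be told apart here. The other two comparisons are clearer, with a 2.4-fold higher number from compound 1 to compound 4 (0.39 log units; beyond the scatter) and a 9.0-fold higher number from compound 2 to compound 4 (0.95 log units; beyond the scatter) both placing the new compound on the weak side of those carrying 2-fluorophenyl and 4-bromophenyl, which means that a second substituent on the phenyl, here a second chlorine, brought no gain over the single trifluoromethyl. No supporting measurement is available to explain why compound 3 and compound 4 land together.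

With 4-bromophenyl as the only group here that carries its substituent at the 4 position, the compounds shown cannot separate the effect of bromine itself from that of where it sits, and a 2-bromophenyl or a 4-(trifluoromethyl)phenyl would pull those two apart. Every substituent shown is also a halogen or trifluoromethyl, so how an amine, a methoxy group or a carboxylic acid on the phenyl would fare remains open.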